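Adding a Methoxy to Compound 3

The compounds below may be only part of what the source reports. "The series", "measured", "known", "first", "only" and "open" are said of these compounds alone.

Measured so far in a functional assay on K562 cells (Homo sapiens) for inhibition, read by sulforhodamine B assay, with a stated time of 48 h, tested at 10 uM; on this read-out higher numbers stand for more inhibition of growth at the one concentration tested and lower numbers for less inhibition of growth:
Compound 1 `COc1ccc(-c2nc3sc(-c4ccccc4)cn3n2)cc1`: 76%
Compound 2 `COc1cc(-c2nc(N)n(CC(=O)Nc3ccc(/C(C)=N\O)cc3)n2)cc(OC)c1OC`: 3.93%
Compound 3 `Clc1ccc(-c2cn3nc(-c4ccccc4)nc3s2)cc1`: 24%

Compound 3, at 24%, stands second highest of the three in this assay. Compound 2 lies lower at 3.93% and compound 1 higher at 76%, and both gaps to compound 3 exceed the usual scatter.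

Compound 4 `COc1ccc(-c2nc3sc(-c4ccc(Cl)cc4)cn3n2)cc1` differs from compound 3 by a single change: methoxy in place of hydrogen on an aromatic carbon. A methoxy stands in place of hydrogen on an aromatic carbon, para to a large group. Going by the values given here, no measured pair isolates this change, so its size can only be expected. Compound 1, which carries the same methoxy but no chlorine, gives 76%, and this is the only basis for expecting a rise. The expected step of a number 34 percentage points higher from compound 3 to compound 4 (beyond the scatter) is upward and beyond the scatter, though it rests on very few compounds. For compound 4 the estimated value is 58%, with an expected range of 28% to 85%.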

Compound 4, percent growth inhibition at one concentration: 38.5%
The estimate for compound 4 lay 19.5 percentage points above the measured number; measured number inside the range.
By their numbers in this assay, from the lowest: compound 2; then compound 3; then compound 4; then compound 1.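

In this assay, the methoxy in place of hydrogen on an aromatic carbon now has a measured effect in the presence of the chlorine: a number 14.5 percentage points higher from compound 3 to compound 4 (beyond the scatter), a modest rise. The reverse view of the same scaffold shows that chloro in place of hydrogen on an aromatic carbon, with the methoxy already present, gives a number 37.5 percentage points lower from compound 1 to compound 4 (beyond the scatter), a large fall, so the methoxy does not keep the high number of compound 1 once the chlorine is there. Nothing measured here explains either step.

The compounds shown leave open whether an amine or a longer alkoxy chain at the methoxy position would raise the number further. They also do not show whether fluoro or a carboxylic acid in place of the chlorine would give a smaller fall.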